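This account rests on a few compounds, and the source may have more. Where it says the series, first, only, none or still open, it means among the compounds named here.

Series notes. Compound 1 `COc1cc(OC)cc(-c2cc3ccccc3c(-c3cccc(N)c3)n2)c1` and compound 2 `COc1cc(OC)cc(-c2cc3ccccc3c(-c3ccc(O)cc3)n2)c1` share one core and differ in a single place. In a functional assay on HCT-15 cells (Homo sapiens) for cytotoxicity, read by CCK-8 assay and cell counting, with a stated time of 72 h (on this read-out higher numbers stand for weaker inhibition and lower numbers for stronger inhibition), compound 1 gives 4080 nM. In this assay compound 2 gives 2780 nM. The change between them is 4-hydroxyphenyl in place of 3-aminophenyl on an aromatic carbon, and the step it made is a 1.5-fold lower number from compound 1 to compound 2 (0.17 log units; within the scatter). Compound 3 `COc1ccc(-c2cc3cc(C)ccc3c(-c3cccc(N)c3)n2)cc1OC` carries the same 3-aminophenyl on a different core; the difference between the core of compound 3 and the core of compound 1 is not broken down here. In this assay compound 3 gives 2700 nM. The values of compound 3, compound 2 and compound 1 all lie within the scatter of one another, so no order among them is read.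

Compound 4 `COc1ccc(-c2cc3cc(C)ccc3c(-c3ccc(O)cc3)n2)cc1OC` is not yet measured. Relative to compound 3 it carries 4-hydroxyphenyl in place of 3-aminophenyl on an aromatic carbon. The surroundings of the place agree word for word with those of the change from compound 1 to compound 2, so the same change is made on the core of compound 3. Among the four compounds this change occurs twice, once measured and once not.

Expectation. Among the measured compounds shown here, the one measured instance of the change is within the scatter, and nothing here indicates the change acts otherwise on the core of compound 3. The expected step is a 1.5-fold lower number from compound 3 to compound 4 (0.18 log units; within the scatter), a size that rests on a 1.5-fold lower number from compound 1 to compound 2 (0.17 log units; within the scatter). Compound 4 is expected at 1800 nM in this assay, with the likely range running from 900 nM to 3600 nM.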

Compound 4, half-maximal inhibitory concentration: 2520 nM
The estimate for compound 4 lay 1.4-fold (0.15 log units) below the measured number; the measured number falls inside the stated range.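

In this assay, placing 4-hydroxyphenyl where 3-aminophenyl stood on the second core gives a 1.1-fold lower number from compound 3 to compound 4 (0.03 log units; within the scatter), so this instance, like the earlier one, yields no readable shift. Set side by side, the two instances do not differ by more than repeated measurement would allow: the same change on two cores in this assay, a 1.5-fold lower number (0.17 log units; within the scatter) from compound 1 to compound 2 and a 1.1-fold lower number (0.03 log units; within the scatter) from compound 3 to compound 4, 1.4-fold (0.14 log units) apart, within the scatter of two such steps. This shows that, on these two cores, the exchange of the two aryl groups leaves the number within the scatter both times; it does not show that the exchange is without effect on any other core, and since neither step is readable, the agreement is between two steps too small to read and not evidence that a real shift carries from one core to another.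

Still open, on these data alone, is whether a different kind of group at this place, such as a carboxylic acid, an amide or a longer chain ending in an amine, would move the number beyond the scatter and give a step large enough to test transfer between cores. Also open, as far as these compounds go, are how the separate differences between the core of compound 1 and the core of compound 3 act on their own, and whether the pattern holds in any other cell line.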